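From morpholin-4-yl to dimethylamino on a carbonyl carbon

The source may report more compounds than this note shows. Statements on the series, on what has been measured and on what is new or still open speak of the compounds shown alone.

In a functional assay on HCT-116 cells (Homo sapiens) for inhibition, read by MTT assay, with a stated time of 72 h (a lower number here means a stronger inhibitor of growth, a higher number a weaker inhibitor of growth), compound 1 `COC(=O)/C=C/c1ccncc1-c1ccc2ccccc2c1` gives 350 nM. Compound 2 `O=C(O)CCNC(=O)/C=C/c1ccncc1-c1ccc2ccccc2c1` has no number, only the entry "not determined" (no result reported). Compound 3 `O=C(/C=C/c1ccncc1-c1ccc2ccccc2c1)N1CCOCC1`, at 6040 nM, holds the higher of the two numbers. Compound 4 `CN(C)C(=O)/C=C/c1ccncc1-c1ccc2ccccc2c1` carries dimethylamino in place of morpholin-4-yl on a carbonyl carbon. Going by the values given here, no measured step shows this swap directly. The one that bears on it is a 17-fold higher number from compound 1 to compound 3 (1.24 log units; beyond the scatter), a large step with morpholin-4-yl in place of methoxy on a carbonyl carbon. Compound 4 does not restore methoxy, so little of that gap is expected to return. The expected step is a 1.5-fold lower number from compound 3 to compound 4 (0.18 log units; within the scatter), with nothing expected beyond the scatter. Compound 4 is estimated at 4000 nM, within an expected range of 1000 nM to 14000 nM.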

Compound 4, concentration for 50% growth inhibition: 4540 nM
Beside the measured number, compound 4's estimate is 1.1-fold (0.05 log units) below it; low and high end bracket the measured number.
By their numbers in this assay, from the lowest: compound 1; then compounds 4 and 3 (each within the scatter of the next).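

Dimethylamino in place of morpholin-4-yl on the carbonyl carbon gives a 1.3-fold lower number from compound 3 to compound 4 (0.12 log units; within the scatter) in this assay and so removing the ring with its oxygen makes no difference that stands out from the scatter. The step of a 13-fold higher number from compound 1 to compound 4 (1.11 log units; beyond the scatter) remains large and shows that the loss against methoxy is not tied to morpholin-4-yl alone. No measurement here explains why methoxy differs from these two groups. On these data alone, it remains open whether a smaller amine such as methylamino, or a longer ester such as ethoxy, on the carbonyl carbon would bring the number back towards that of compound 1.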